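A Cytidine-Type Amide Series: Swapping Carboxy for Methylsulfanyl

This account rests on a few compounds, and the source may have more. Where it says the series, first, only, none or still open, it means among the compounds named here.

This piece concerns a small set of compounds sharing one core, a ribose-bearing pyrimidinone joined through an amide to an amino-acid unit that carries a long acyl chain. Compound 1 is `CCCCCCCCCCCCCC(=O)N[C@@H](CCC(=O)O)C(=O)Nc1ccn([C@H]2O[C@@H](CO)[C@H](O)[C@H]2O)c(=O)n1`, compound 2 is `CCCCCCCCCC(=O)N[C@H](C(=O)Nc1ccn([C@H]2O[C@@H](CO)[C@H](O)[C@H]2O)c(=O)n1)C(C)C` and compound 3 is `CCCCCCCCCC(=O)N[C@@H](CCCNC(=N)N)C(=O)Nc1ccn([C@H]2O[C@@H](CO)[C@H](O)[C@H]2O)c(=O)n1`. In a functional assay on HL-60 cells (Homo sapiens) for cytotoxicity, read by MTT assay, with a stated time of 48 h (a higher number here means a weaker inhibitor, a lower number a stronger inhibitor), compound 1 gives 502 nM, compound 3 gives 584 nM and compound 2 gives 2040 nM. Compound 1 therefore holds the lowest number of the three; the gap to compound 3 is within the scatter, while the gap to compound 2 is beyond it.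

Within the data shown here, the one measured step that changes the group on the saturated chain carbon bound to an amide-type nitrogen and a carbonyl carbon is a 3.5-fold lower number from compound 2 to compound 3 (0.54 log units; beyond the scatter), so the group at that position can move the number modestly.

Compound 4 is `CCCCCCCCCCCCCC(=O)N[C@@H](CCSC)C(=O)Nc1ccn([C@H]2O[C@@H](CO)[C@H](O)[C@H]2O)c(=O)n1`. It differs from compound 1 as methylsulfanyl in place of carboxy on a saturated chain carbon, three bonds along the chain from an amide-type nitrogen and a carbonyl carbon. Among the measured compounds shown here, no measured pair tests carboxy against methylsulfanyl, so the direction cannot be read from the data; given that compound 2 and compound 3 differ only modestly there, a step of at most modest size is expected. The estimate for compound 4 is 650 nM, with a range from 220 nM to 1900 nM, meaning an expected step of a 1.3-fold higher number from compound 1 to compound 4 (0.11 log units; within the scatter).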

Compound 4, half-maximal inhibitory concentration: 272 nM
The estimate for compound 4 lay 2.4-fold (0.38 log units) above the measured number; low and high end bracket the measured number.
By their numbers in this assay, from the lowest: compounds 4, 1 and 3 (each within the scatter of the next, the first and the last beyond it); then compound 2.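

Carboxy and methylsulfanyl had not been set against each other in the earlier compounds, and this direct pair gives a 1.8-fold lower number from compound 1 to compound 4 (0.27 log units; within the scatter) in this assay and so does not separate the two groups. On a saturated chain carbon, three bonds along the chain from an amide-type nitrogen and a carbonyl carbon, a group with a hydrogen-bond donor can give way to one without any while the number stays within the scatter, so compound 4 shows that this pair does not depend on the carboxy for a value in this range. The side chain is still not indifferent to every change, as a 3.5-fold lower number from compound 2 to compound 3 (0.54 log units; beyond the scatter) lies beyond the scatter, although that step replaces different groups and sits one bond nearer the amide-type nitrogen.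

The compounds shown do not tell how a primary amine, a hydroxyl or a longer chain ending in carboxy would behave at this place, or whether the same swap would give a similar step with a different acyl chain on the shared core. Nothing measured here offers an explanation for the size of the step between these two groups.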